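A Methyl Added to the Piperidine Ring of Compound 1

The compounds below may be only part of what the source reports. "The series", "measured", "known", "first", "only" and "open" are said of these compounds alone.

compound 1 `COc1ccc(/C=N/NC(=O)Nc2ccc(Oc3ccnc4cc(OCCCN5CCCCC5)c(OC)cc34)c(F)c2)cc1`: 660 nM
compound 2 `COc1cc2c(Oc3ccc(NC(=O)N/N=C/c4ccncc4)cc3F)ccnc2cc1OCCCN1CCCCC1`: 980 nM

In a functional assay on MKN-45 cells (Homo sapiens) for cytotoxicity, read by MTT assay, with a stated time of 72 h (a higher number here means a weaker inhibitor, a lower number a stronger inhibitor), compound 1 gives 660 nM, the lowest of the two numbers, and compound 2 gives 980 nM. Going by the values given here, the only measured step, a 1.5-fold higher number from compound 1 to compound 2 (0.17 log units; within the scatter), alters the aryl group on the carbon doubly bonded to nitrogen, far from the saturated ring. Compound 3 `COc1ccc(/C=N/NC(=O)Nc2ccc(Oc3ccnc4cc(OCCCN5CCC(C)CC5)c(OC)cc34)c(F)c2)cc1` differs from compound 1 by methyl in place of hydrogen on a saturated ring carbon. Among the compounds with values here, no measured step touches this ring, so nothing beyond the scatter is expected: no change at the digits printed from compound 1 to compound 3 (within the scatter). Compound 3 is therefore estimated at 660 nM, with a range from 300 nM to 1500 nM.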

Compound 3, half-maximal inhibitory concentration: 470 nM
Beside the measured number, compound 3's estimate is 1.4-fold (0.15 log units) above it; the measured number falls inside the stated range.
By their numbers in this assay, from the lowest: compounds 3, 1 and 2 (each within the scatter of the next, the first and the last beyond it).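

In this assay, going by these compounds alone, the earlier step changed only the aryl group on the carbon doubly bonded to nitrogen, whereas going from piperidin-1-yl to 4-methylpiperidin-1-yl gives a 1.4-fold lower number from compound 1 to compound 3 (0.15 log units; within the scatter) and so tests the saturated ring for the first time. A methyl on this ring carbon, three ring bonds from the ring nitrogen, therefore leaves the number within the scatter. Nothing available explains this result. On these data alone, whether an ethyl or hydroxyl group on this ring carbon would do the same remains open. So does the outcome of replacing the piperidine ring with morpholine.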